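The compounds below may be only part of what the source reports. "The series", "measured", "known", "first", "only" and "open" are said of these compounds alone.

Of the compounds shown here, three on a shared core have been measured so far in an ADME assay on L6 cells (Rattus norvegicus) for cytotoxicity, with a stated time of 72 h (a lower number here means a stronger inhibitor, a higher number a weaker inhibitor), and give a narrow spread of numbers. Compound 1 (`CN(C)C12CC(OC(=O)CN3CCCC3)C(C(c3ccccc3)C1)C(c1ccccc1)C2`) gives 32700 nM here, compound 2 (`CCN(CC)CC(=O)OC1CC2(N3CCCCC3)CC(c3ccccc3)C1C(c1ccccc1)C2`) gives 23900 nM here, and compound 3 (`O=C(CN1CCCCC1)OC1CC2(N3CCCCC3)CC(c3ccccc3)C1C(c1ccccc1)C2`) gives 60400 nM as the third reading. Compound 3 and compound 1 lie within the scatter of each other, while compound 3 stands clear of compound 2 by a modest margin. Compound 4 (`O=C(CN1CCCC1)OC1CC2(N3CCCCC3)CC(c3ccccc3)C1C(c1ccccc1)C2`), not yet measured, differs from compound 3 in one place (pyrrolidin-1-yl in place of piperidin-1-yl on a saturated chain carbon bound to a carbonyl carbon), on a saturated chain carbon bound to a carbonyl carbon. Among the measured compounds shown here, the only measured step at this place is a 2.5-fold higher number from compound 2 to compound 3 (0.40 log units; beyond the scatter) and it is modest, with piperidin-1-yl in place of diethylamino. Compound 4 also shares pyrrolidin-1-yl at that place with compound 1, though the two differ elsewhere on the core, and compound 1 reads 32700 nM in this assay without leaving the scatter of compound 3. A change within the scatter, leaning if anything toward a lower number, is therefore expected, and the estimated step is a 1.4-fold lower number from compound 3 to compound 4 (0.16 log units; within the scatter) in this assay for now. The estimate for compound 4 is 42000 nM with an expected range from 20000 nM to 85000 nM in this measurement.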

Compound 4, half-maximal inhibitory concentration: 16400 nM
Beside the measured number, compound 4's estimate is 2.6-fold (0.41 log units) above it; measured number below the stated range.
By their numbers in this assay, from the lowest: compounds 4, 2, 1 and 3 (each within the scatter of the next, the first and the last beyond it).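

In this assay, the change from piperidin-1-yl to pyrrolidin-1-yl on a saturated chain carbon bound to a carbonyl carbon gives a 3.7-fold lower number from compound 3 to compound 4 (0.57 log units; beyond the scatter) and shows that this place responds to a swap of a six-membered ring for a five-membered one. Compounds 2, 3 and 4 differ only at this place, and a 1.5-fold lower number from compound 2 to compound 4 (0.16 log units; within the scatter) sets diethylamino and pyrrolidin-1-yl within the scatter of each other, so among these three it is piperidin-1-yl alone that stands apart, and having a ring at this place does not by itself set the number. Among the compounds shown here, with pyrrolidin-1-yl on the chain, a 2.0-fold lower number from compound 1 to compound 4 (0.30 log units; within the scatter) is the first reading at the saturated ring carbon, where piperidin-1-yl in place of dimethylamino stays within the scatter.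

No supporting data bear on why these groups differ at the chain carbon. From the compounds shown here alone, it also remains open whether a morpholin-4-yl or a seven-membered azepan-1-yl ring at this place would read with compound 3 or with compound 4, and whether the same swap would give a step of similar size with dimethylamino on the saturated ring carbon.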